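This account rests on a few compounds, and the source may have more. Where it says the series, first, only, none or still open, it means among the compounds named here.

Measured compounds:
compound 1 `CC(C)=CCC1Cc2c(OCCCNC(=O)c3ccco3)cc(=O)n(CCCO)c2CC1(C)C` — 4.3%
compound 2 `CC(C)=CCC1Cc2c(OC(=O)Nc3ccc(F)c(Cl)c3)cc(=O)n(CCCO)c2CC1(C)C` — 0%

In a functional assay on PANC-1 cells (Homo sapiens) for inhibition, read by MTT assay, with a stated time of 24 h, tested at 10 uM (a lower number here means less inhibition, a higher number more inhibition at the concentration tested (going by the name of the read-out)), compound 2 gives 0%. For the measured compounds named here, its only neighbour is compound 1, which gives 4.3% in this assay; the step of a number 4.3 percentage points lower from compound 1 to compound 2 (within the scatter) lies within the scatter, so the two compounds are not separated by this read-out.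

Compound 3 `CC(C)=CCC1Cc2c(OC(=O)Nc3ccc(Cl)cc3)cc(=O)n(CCCO)c2CC1(C)C` differs from compound 2 in one place: 4-chlorophenyl in place of 3-chloro-4-fluorophenyl on an amide-type nitrogen. Going by the values given here, no measured step changes the aryl group on this carbamate nitrogen, so nothing shows directly what this exchange does. Among the compounds with values here, the one step that is known, from compound 1 to compound 2, swapped a far larger piece on the ring oxygen and still stayed within the scatter, and both compounds sit near the bottom of the scale. Compound 3 is therefore expected to show no step beyond the scatter, with a number 3 percentage points higher from compound 2 to compound 3 (within the scatter). Compound 3 is estimated at 3%, in a range from 0% to 15%.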

Compound 3, a percentage reported as inhibition, at one concentration (the size of the read-out at that concentration, not a potency): 0%
The estimate for compound 3 lay 3 percentage points above the measured number, and the stated range covers the measured number.
By their numbers in this assay, from the lowest: compounds 2, 3 and 1 (each within the scatter of the next).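

In this assay, for the compounds shown here, the step of no change at the digits printed from compound 2 to compound 3 (within the scatter) gives the first direct reading at the amide-type nitrogen: 4-chlorophenyl in place of 3-chloro-4-fluorophenyl does not separate the two compounds. The exchange of 3-(((furan-2-yl)carbonyl)amino)propyl for (4-chlorophenyl)carbamoyl on the oxygen on the aromatic ring gives a number 4.3 percentage points lower from compound 1 to compound 3 (within the scatter), so a second carbamoyl group also stays undistinguished from the furan amide. No independent evidence bears on why these changes leave the read-out flat.

All three compounds lie within the scatter of one another at a single concentration, so this read-out cannot show whether the aryl group on this nitrogen matters at all. On these data alone, what an amine or a carboxylic acid on that phenyl ring would do remains open.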